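Aryl to benzyl exchange on the ring nitrogen of the shared core

A few compounds are considered here, and "the series" means these few. Any claim that something is new, unique, unknown or untested is made for them only; others in the source may bear on it.

Measured compounds:
compound 1 `Cc1ccc(-n2cc(CNC(=O)c3cccc4c3cnn4C(C)C)nn2)c(C)c1`: 10600 nM
compound 2 `CC(C)n1ncc2c(C(=O)NCc3cn(-c4ccc(C(F)(F)F)cc4)nn3)cccc21`: 38600 nM

In a functional assay on PC-3 cells (Homo sapiens) for inhibition, read by MTT assay, with a stated time of 72 h (on this read-out lower numbers stand for stronger inhibition and higher numbers for weaker inhibition), compound 2 gives the highest of the two numbers; its nearest neighbour is compound 1, with a 3.6-fold higher number from compound 1 to compound 2 (0.56 log units; beyond the scatter). Compound 3 `COc1ccc(Cn2cc(CNC(=O)c3cccc4c3cnn4C(C)C)nn2)cc1` differs from compound 2 by 4-methoxybenzyl in place of 4-(trifluoromethyl)phenyl on an aromatic nitrogen. Among the compounds with values here, the only measured step touching this aromatic nitrogen is that from compound 1 to compound 2, a modest one beyond the scatter, so a step of similar size in either direction is plausible, with no direction clearly favoured. The estimate for compound 3 is 20000 nM (range 5000 nM to 80000 nM), an expected step of a 1.9-fold lower number from compound 2 to compound 3 (0.29 log units; within the scatter).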

Compound 3, half-maximal inhibitory concentration: 34000 nM
Beside the measured number, compound 3's estimate is 1.7-fold (0.23 log units) below it, and the stated range covers the measured number.
By their numbers in this assay, from the lowest: compound 1; then compounds 3 and 2 (each within the scatter of the next).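

Putting 4-methoxybenzyl on this aromatic nitrogen in place of 4-(trifluoromethyl)phenyl gives a 1.1-fold lower number from compound 2 to compound 3 (0.06 log units; within the scatter), so this aryl to benzyl exchange leaves no readable difference. The same benzyl group in place of 2,4-dimethylphenyl gives a 3.2-fold higher number from compound 1 to compound 3 (0.51 log units; beyond the scatter), so among these three compounds only compound 1 stands apart, and only modestly. Nothing available here bears on the reason for this result.

From the compounds shown here alone, how a carboxylic acid or a longer chain ending in an amine would read on this nitrogen remains open. So does whether 2,4-dimethylbenzyl would track compound 1 or compound 3.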